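The source may hold more compounds than are shown below. What is called first, only, known or untested is meant among the compounds shown, and "the series" means these compounds.

Measured compounds:
compound 1 `O=C(CC1c2ccccc2N=C(SCCCCCN2CCCC2)N1c1ccc(-c2ccc(F)cc2)cc1)NCc1ccc(F)cc1` gives 7700 nM in a functional assay on HCT-116 cells (Homo sapiens) for cytotoxicity, read by MTT assay, with a stated time of 48 h; on this read-out lower numbers stand for stronger inhibition and higher numbers for weaker inhibition
compound 2 `O=C(CC1c2ccccc2N=C(SCCCCCN2CCCC2)N1c1ccccc1)NCc1ccc(F)cc1` gives 27100 nM in this assay

On these two numbers compound 1 stands lowest, so it is the stronger of the pair. For the measured compounds named here, the one measured step, a 3.5-fold higher number from compound 1 to compound 2 (0.55 log units; beyond the scatter), comes from putting hydrogen in place of 4-fluorophenyl on an aromatic carbon of the shared core.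

Compound 3 `CN(C)CCCCCSC1=Nc2ccccc2C(CC(=O)NCc2ccc(F)cc2)N1c1ccc(-c2ccc(F)cc2)cc1` keeps that 4-fluorophenyl and changes a different part: dimethylamino in place of pyrrolidin-1-yl on a saturated chain carbon, five bonds along the chain from a sulfur. The amine at the end of the chain is thus trimmed from a ring to an open pair of methyl groups, while the chain itself, the sulfur and the rest of the core stay as in compound 1.

Going by the values given here, no measured step touches this chain amine, so the step from compound 1 to compound 2 does not bear on the change at hand. With nothing to point either way, the expectation for this assay is a step of about a 1.2-fold higher number from compound 1 to compound 3 (0.07 log units; within the scatter), that is, no movement beyond the scatter, with a wide range. Compound 3 is therefore estimated at 9000 nM, between 3500 nM and 25000 nM.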

Compound 3, half-maximal inhibitory concentration: 9300 nM
Estimate against measurement, compound 3: 1.0-fold (0.01 log units) below; low and high end bracket the measured number.
By their numbers in this assay, from the lowest: compounds 1 and 3 (each within the scatter of the next); then compound 2.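

In this assay, trimming the pyrrolidin-1-yl ring at the end of the chain to dimethylamino gives a 1.2-fold higher number from compound 1 to compound 3 (0.08 log units; within the scatter), so on this read-out the two amine ends cannot be told apart. For the compounds shown here, this is the first information about this end of the molecule, and it shows that the ring itself is not needed to keep the number in this range, even though the group loses its ring and goes from 5 heavy atoms to 3. The size of the 4-fluorophenyl step, a 3.5-fold higher number from compound 1 to compound 2 (0.55 log units; beyond the scatter), is therefore not matched here, where the swap stays within the usual scatter, and no supporting measurement is available to explain why the two amines read alike.

Both amine ends shown are small and carry two carbon groups on the nitrogen, so it remains open whether a bulkier piperidin-1-yl or morpholin-4-yl group, a simple primary amine, or a hydroxyl group with no nitrogen at all would read the same. Dimethylamino also appears here only together with the 4-fluorophenyl group and the five-carbon chain, which leaves open how it would behave with hydrogen in that place or on a shorter chain.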